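Dimethylamino in Place of Trifluoromethyl on the Aryl Ring

A few compounds are considered here, and "the series" means these few. Any claim that something is new, unique, unknown or untested is made for them only; others in the source may bear on it.

Measured compounds:
compound 1 `CC(C)c1cccc(C(C)C)c1NC(=O)Nc1nc2ccccc2n1-c1cccc(Cl)c1`, in an assay on isolated protein for displacement of a labelled ligand from acyl-CoA:cholesterol acyltransferase (Oryctolagus cuniculus) (on this read-out lower numbers stand for stronger inhibition and higher numbers for weaker inhibition), compound 1 gives 20 nM
compound 2 `CC(C)c1cccc(C(C)C)c1NC(=O)Nc1nc2ccccc2n1-c1ccccc1C(F)(F)F`, in this assay compound 2 gives 72 nM

Within the data shown here, compound 2 stands at the higher of the two numbers; the only measured step, a 3.6-fold higher number from compound 1 to compound 2 (0.56 log units; beyond the scatter), came from changing the whole aryl group on the aromatic nitrogen. Compound 3 `CC(C)c1cccc(C(C)C)c1NC(=O)Nc1nc2ccccc2n1-c1ccccc1N(C)C` differs from compound 2 by dimethylamino in place of trifluoromethyl on an aromatic carbon, ortho to a large group. That single step bears on it only loosely, so no step beyond the scatter is expected in this assay; the expected step is a 1.0-fold lower number from compound 2 to compound 3 (0.01 log units; within the scatter). Compound 3 is estimated at 70 nM, between 20 nM and 250 nM.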

Compound 3, half-maximal inhibitory concentration: 41 nM
The estimate for compound 3 lay 1.7-fold (0.23 log units) above the measured number; the measured number falls inside the stated range.
By their numbers in this assay, from the lowest: compound 1; then compounds 3 and 2 (each within the scatter of the next).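

In this assay, dimethylamino in place of trifluoromethyl on this aromatic carbon, ortho to a large group, gives a 1.8-fold lower number from compound 2 to compound 3 (0.24 log units; within the scatter), so the assay does not separate these two groups here. The 2-(dimethylamino)phenyl group still gives a 2.1-fold higher number from compound 1 to compound 3 (0.31 log units; beyond the scatter), so, like 2-(trifluoromethyl)phenyl, it stands apart from 3-chlorophenyl, though only modestly. Nothing available accounts for either step. The compounds shown leave open whether a primary amine or a carboxylic acid on this aromatic carbon would also stay within the scatter of compound 2.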